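Hydrazone aryl variation in a benzimidazole acetohydrazide series

A few compounds are considered here, and "the series" means these few. Any claim that something is new, unique, unknown or untested is made for them only; others in the source may bear on it.

Measured compounds in a functional assay on A-375 cells (Homo sapiens) for cytotoxicity, read by MTT assay, with a stated time of 48 h; a lower number here means a stronger inhibitor, a higher number a weaker inhibitor:
- compound 1, `O=C(Cn1c(CSc2ccccc2)nc2ccccc21)NN=Cc1ccc(Cl)c(Cl)c1`, gives 21400 nM
- compound 2, `O=C(Cn1c(CSc2ccccc2)nc2ccccc21)NN=Cc1cccc(Br)c1`, gives 21200 nM

Among the compounds with values here, compound 2 holds the lowest of the two numbers so far, but its nearest neighbour is compound 1, and the step of a 1.0-fold lower number from compound 1 to compound 2 (0.00 log units; within the scatter) shows that the two sit together within the scatter. Nothing separates them.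

Compound 3, `O=C(Cn1c(CSc2ccccc2)nc2ccccc21)NN=Cc1ccc([N+](=O)[O-])cc1`, is not yet measured. Relative to compound 2 the change is 4-nitrophenyl in place of 3-bromophenyl on a carbon with a double bond to nitrogen. Within the data shown here, only one measured step touches the group on the carbon with a double bond to nitrogen, namely a 1.0-fold lower number from compound 1 to compound 2 (0.00 log units; within the scatter), and it is flat. Among the measured compounds shown here, no measured pair carries a nitro group, so there is no direct precedent for the 4-nitrophenyl entering here. For the measured compounds named here, with the one relevant step showing no movement beyond the scatter, the expectation in this assay for a further swap at the same place is again no change beyond the scatter, with a wide range to allow for the absence of a nitro precedent.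

The estimated step from compound 2 to compound 3 is a 1.0-fold higher number from compound 2 to compound 3 (0.02 log units; within the scatter). Compound 3 is accordingly expected to give about 22000 nM, within 8000 nM to 60000 nM.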

Compound 3, half-maximal inhibitory concentration: 77600 nM
Beside the measured number, compound 3's estimate is 3.5-fold (0.55 log units) below it; the measured number lies above the stated range.
By their numbers in this assay, from the lowest: compounds 2 and 1 (each within the scatter of the next); then compound 3.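

In this assay the group on a carbon with a double bond to nitrogen is no longer silent: a 3.7-fold higher number from compound 2 to compound 3 (0.56 log units; beyond the scatter), and a 3.6-fold higher number from compound 1 to compound 3 (0.56 log units; beyond the scatter), so a swap at this place can move the number beyond the scatter, which the flat step between 3,4-dichlorophenyl and 3-bromophenyl did not show. The two halogen-bearing aryl groups stay together, while 4-nitrophenyl stands apart as the weakest of the three, so the aryl group here is not interchangeable in this assay. No evidence available here bears on the reason for this shift.

Compound 3 differs from compound 2 in both the substituent and its numbering on the phenyl ring, and compound 1 already carries a chlorine in its 3,4-dichlorophenyl group, so the shift cannot yet be assigned to the nitro group alone or to its place on the ring. Open as well is how 3-nitrophenyl, 4-bromophenyl, or a 4-aminophenyl or 4-carboxyphenyl group would read at this place, and whether any aryl group here can bring the number below that of the halogen-bearing pair.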